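A few compounds are considered here, and "the series" means these few. Any claim that something is new, unique, unknown or untested is made for them only; others in the source may bear on it.

Three compounds of the series carry numbers in an assay on nucleic acid for inhibition of Nucleic Acid, read by fluorescence, tested at 100 uM; on this read-out lower numbers stand for less inhibition and higher numbers for more inhibition at the one concentration tested (going by the name of the read-out). Compound 1, `CC(C)CCN(C)Cc1cn(C2CCCCC2OC(=O)c2ccccc2)nn1`, gives 26%. Compound 2, `O=C(OCC(O)Cn1cc(CN2CCN(c3ccccc3)CC2)nn1)c1ccccc1`, gives 11%. Compound 3, `CCCCC(O)Cn1cc(CN(C)CCCc2ccccc2)nn1`, gives 37%. On these three numbers compound 1 stands second highest: its nearest neighbour is compound 3, whose number lies higher by a gap beyond the scatter, and its furthest is compound 2, whose number lies lower, also beyond the scatter. No two of the measured compounds differ in one place only, so no single change has yet been read against a measurement.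

Compound 4, `CN(Cc1cn(C2CCCCC2OC(=O)c2ccccc2)nn1)CC1CCCCC1`, is not yet measured in this assay. Set against compound 1 it carries cyclohexyl in place of isobutyl on a saturated chain carbon bound to an amine nitrogen. The change is confined to one substituent on the saturated chain carbon bound to the amine nitrogen; the rest of compound 1 is kept. Among the measured compounds shown here, with no measured pair of this kind to draw on, the expected step is a small one, a number 4 percentage points higher from compound 1 to compound 4 (within the scatter), rising a little if anything and plausibly staying within the scatter. Compound 4 is therefore estimated at 30% in this assay, with a range from 12% to 50%.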

Compound 4, a percentage reported as inhibition, at one concentration (the size of the read-out at that concentration, not a potency): 32%
For compound 4 the middle estimate is 2 percentage points below the measured one; measured number inside the range.
By their numbers in this assay, from the lowest: compound 2; then compounds 1, 4 and 3 (each within the scatter of the next, the first and the last beyond it).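

In this assay, among the compounds shown here, cyclohexyl in place of isobutyl on a saturated chain carbon bound to an amine nitrogen gives a number 6 percentage points higher from compound 1 to compound 4 (within the scatter), the first single change that can be read against a measurement. At this place, an open branched group of 4 carbon atoms and a six-membered non-aromatic ring of 6 carbon atoms are not told apart by this read-out, so the position accepts this change with no shift beyond the scatter. No measurement at hand accounts for this step or links it to any property of either group.

Both groups carry no hydrogen-bond donors or acceptors and no net charge, which leaves open whether a carboxylic acid or a primary amine on the same chain carbon would give a step beyond the scatter. Compound 2 and compound 3 differ from compound 1 and compound 4 in more than one place, so the gaps to them cannot be read as steps, and the contribution of the rest of the core remains unresolved.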